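Adding a Dimethylamino Group to the Ring of Compound 3

A few compounds are considered here, and "the series" means these few. Any claim that something is new, unique, unknown or untested is made for them only; others in the source may bear on it.

Among the two plain numbers shown in an ADME assay on cells for inhibition of cytochrome P450 11B1, mitochondrial (Homo sapiens), read by HPLC, with a stated time of 60 min (a lower number here means a stronger inhibitor, a higher number a weaker inhibitor), compound 3 `Fc1cc2nc(-c3cncnc3)n(C3CC3)c2cc1F` has the lowest: compound 3 gives 2270 nM. The nearest neighbour, compound 1 `Fc1ccc2nc(-n3ccnn3)n(C3CC3)c2c1`, gives 9070 nM in this assay, a gap that lies beyond the scatter. Compound 2 `Fc1ccc2nc(-c3cccnn3)n(C3CC3)c2c1` gives > 10000 nM in this assay, and this is a limit of the assay rather than a number (the limit of > 10000 nM in this assay, at which 1 of the 3 values shown sits). Going by the values given here, the only measured step, an at least 1.1-fold higher number from compound 1 to compound 2 (0.04 log units; that floor lies within the scatter), exchanges one aromatic ring for another at the same place on the shared core.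

Compound 4 `CN(C)c1ncncc1-c1nc2cc(F)c(F)cc2n1C1CC1` differs from compound 3 by dimethylamino in place of hydrogen on an aromatic carbon; the new group sits next to the ring nitrogen, ortho to a large group, and opposite the ring nitrogen. Among the compounds with values here, no measured step adds a group onto this ring; the step from the triazolyl to the pyridazinyl ring replaces the whole ring and its floor sits within the scatter, so it gives no direction for this change. The expected step of a 1.3-fold higher number from compound 3 to compound 4 (0.12 log units; within the scatter) is therefore one that stays within the scatter. Compound 4 is expected to give about 3000 nM in this assay, estimated to fall between 800 nM and 12000 nM.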

Compound 4, half-maximal inhibitory concentration: 4630 nM
Compound 4: the middle estimate sits 1.5-fold (0.19 log units) below what was measured, within the range that was stated.
By their numbers in this assay, from the lowest: compound 3; then compounds 4 and 1 (each within the scatter of the next). At a limit, above all of these: compound 2.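

In this assay, going by these compounds alone, the change gives a 2.0-fold higher number from compound 3 to compound 4 (0.31 log units; beyond the scatter) and this is the first measured step that adds a group onto this ring rather than replacing a whole ring. Unlike the earlier step, which was only a floor within the scatter, this one has a direction: the number rises when dimethylamino replaces hydrogen on this aromatic carbon, next to the ring nitrogen and ortho to a large group. The rise is modest, compound 4 still gives a plain number of 4630 nM in this assay, and nothing among the data shown accounts for the step.

The compounds shown hold a single added group at this place, so they leave open whether a smaller amine such as methylamino, a ring amine such as morpholine, or a methoxy group would raise the number in the same way, or by as much. Going by these compounds, whether dimethylamino would give a step of this size on the ring of another compound, with a different group on the shared core, also remains open.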